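A benzyl swap on compound 1

This account rests on a few compounds, and the source may have more. Where it says the series, first, only, none or still open, it means among the compounds named here.

In a functional assay on HeLa cells (Homo sapiens) for inhibition, read by CCK-8 assay, with a stated time of 48 h (a lower number here means a stronger inhibitor, a higher number a weaker inhibitor), compound 1 (`O=C(NCCNS(=O)(=O)c1ccc(-c2ccccc2O[C@H]2CC[C@H](O)CC2)s1)Nc1cc(C(F)(F)F)cc(C(F)(F)F)c1`) reads > 20000 nM, which is a limit and not a number. Compound 3 (`COc1ccc(NC(=O)NCCNS(=O)(=O)c2ccc(-c3ccccc3Oc3ccc([N+](=O)[O-])c([N+](=O)[O-])c3)s2)cc1`) also stops at a limit, > 20000 nM. Compound 2 (`O=S(=O)(NCCNC(=S)Nc1cc(C(F)(F)F)cc(C(F)(F)F)c1)c1ccc(-c2ccccc2OCc2ccccc2)s1`) does return a number, 4700 nM. Compound 4 (`O=C(NCCNS(=O)(=O)c1ccc(-c2ccccc2OCc2ccccc2)s1)Nc1cc(C(F)(F)F)cc(C(F)(F)F)c1`) has not yet been measured. It differs from compound 1 by benzyl in place of 4-hydroxycyclohexyl on an oxygen on an aromatic ring, with benzyl in place of 4-hydroxycyclohexyl on an oxygen on an aromatic ring. The expectation rests on compound 2, which also carries benzyloxy and gives 4700 nM. A clear step towards stronger inhibition in this assay is expected, estimated as an at least 3.3-fold lower number from compound 1 to compound 4 (0.52 log units; beyond the scatter). The estimated value for compound 4 is 6000 nM, with an expected range of 2000 nM to 20000 nM.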

Compound 4, half-maximal inhibitory concentration: 13500 nM
Beside the measured number, compound 4's estimate is 2.3-fold (0.35 log units) below it, within the range that was stated.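

Benzyl in place of 4-hydroxycyclohexyl on an oxygen on an aromatic ring gives an at least 1.4-fold lower number from compound 1 to compound 4 (0.17 log units; that floor lies within the scatter) and brings this position from a limit to a measured value. That floor alone does not clear the usual scatter. Compound 1 stops at a limit and not a number, so the full size of the step cannot be read: the limit of > 20000 nM in this assay, at which 2 of the 4 values shown sit.

The compounds shown do not separate the aromatic ring from the loss of the hydroxyl, which plain cyclohexyl on the same oxygen could do. As far as these compounds go, how a phenethyl group, or an amine on the benzyl ring, would read in this assay also stays open.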